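Swapping the aryl group on the shared core of compound 3

The source may report more compounds than this note shows. Statements on the series, on what has been measured and on what is new or still open speak of the compounds shown alone.

Three compounds share one core and differ only in the aryl group attached to a nitrogen on an aromatic ring. Compound 1 `COc1cc(NC(=O)Nc2cc(Nc3ccc(C(C)(C)C)cc3)ncn2)cc(OC)c1` gives 17.5% in a functional assay on NCI-H520 cells (Homo sapiens) for inhibition, read by MTT assay, with a stated time of 48 h, tested at 10 uM; a lower number here means less inhibition, a higher number more inhibition at the concentration tested (going by the name of the read-out). Compound 2 `COc1cc(NC(=O)Nc2cc(Nc3ccc(C)c(F)c3)ncn2)cc(OC)c1` gives 30.6%. Compound 3 `COc1cc(NC(=O)Nc2cc(Nc3cc(I)ccc3OC)ncn2)cc(OC)c1` gives 55%, the highest of the three numbers; the steps of a number 24.4 percentage points higher from compound 2 to compound 3 (beyond the scatter) and a number 37.5 percentage points higher from compound 1 to compound 3 (beyond the scatter) are both beyond the scatter.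

Compound 4 `COc1cc(NC(=O)Nc2cc(Nc3ccc(OC)c(C)c3)ncn2)cc(OC)c1` is not yet measured. Its change from compound 3 is 4-methoxy-3-methylphenyl in place of 5-iodo-2-methoxyphenyl on a nitrogen on an aromatic ring. Within the data shown here, two measured steps bear on this, since both put the 5-iodo-2-methoxyphenyl group in place of another aryl group and both raised the number: a number 37.5 percentage points higher from compound 1 to compound 3 (beyond the scatter) and a number 24.4 percentage points higher from compound 2 to compound 3 (beyond the scatter). Removing that group is therefore expected to lower the number, and a drop of modest size is expected, a number 23 percentage points lower from compound 3 to compound 4 (beyond the scatter). Compound 4 is estimated at 32%, within a range from 15% to 50%.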

Compound 4, a percentage reported as inhibition, at one concentration (the size of the read-out at that concentration, not a potency): 13.5%
For compound 4 the middle estimate is 18.5 percentage points above the measured one; the whole stated range lies above it.
By their numbers in this assay, from the lowest: compounds 4 and 1 (each within the scatter of the next); then compound 2; then compound 3.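

In this assay, among these compounds, the earlier compounds showed only that 5-iodo-2-methoxyphenyl stood above two aryl groups with no methoxy, whereas the 4-methoxy-3-methylphenyl group of compound 4 also carries a methoxy, and the result is a number 41.5 percentage points lower from compound 3 to compound 4 (beyond the scatter). A methoxy on this aryl ring is therefore not enough for a high number here, as a number 17.1 percentage points lower from compound 2 to compound 4 (beyond the scatter) also shows, while a number 4 percentage points lower from compound 1 to compound 4 (within the scatter) does not separate compound 4 from the 4-(tert-butyl)phenyl compound. The change removes iodine and also alters where the methoxy sits, so this single step cannot divide the drop between the two. Nothing measured here explains the drop. The compounds shown leave open whether iodine or the methoxy placement carries the number; a 5-bromo-2-methoxyphenyl group, or a 2-methoxyphenyl group with no halogen, would help pull the two apart.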